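The compounds below may be only part of what the source reports. "The series", "measured", "known", "first", "only" and "open" are said of these compounds alone.

Three ureas on one shared core have been examined in an ADME assay on the whole organism with Oryza sativa as the target, tested at 1 uM; on this read-out higher numbers stand for a weaker effect at the one concentration tested and lower numbers for a stronger effect. Compound 1 `C[C@@H](NC(=O)Nc1ccccc1Cl)c1ccccc1` gives 103%. Compound 2 `C[C@@H](NC(=O)Nc1cccc(Cl)c1)c1ccccc1` has the same atoms as compound 1 joined differently, and in this assay compound 2 gives 91%; the difference between the two cores is not broken down here, and the two values alone show that compound 2 reads beyond the scatter from compound 1. Compound 3 `C[C@@H](NC(=O)Nc1ccc(Cl)cc1Cl)c1ccccc1` gives 99%. The change from compound 1 to compound 3 is chloro in place of hydrogen on an aromatic carbon, and it made a step of a number 4 percentage points lower from compound 1 to compound 3 (within the scatter). Compound 2 and compound 3 lie within the scatter of each other.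

The still unmeasured compound 4 `C[C@@H](NC(=O)Nc1ccc(Cl)c(Cl)c1)c1ccccc1` arises from compound 2 by chloro in place of hydrogen on an aromatic carbon. This is the same kind of change as that from compound 1 to compound 3, not the same: in compound 4 the entering chloro is ortho to a chloro group, whereas in compound 3 it is meta to a chloro group. Because the earlier step of a number 4 percentage points lower from compound 1 to compound 3 (within the scatter) stayed within the scatter, a step of a number 3 percentage points lower from compound 2 to compound 4 (within the scatter) is expected in this assay. Compound 4 is accordingly estimated at 88%, between 75% and 101%.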

Compound 4, a percentage reported as activity, at one concentration (the size of the read-out at that concentration, not a potency): 96%
Compound 4: middle estimate off by 8 percentage points, on the low side; measured number inside the range.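

In this assay the added chloro gave a number 5 percentage points higher from compound 2 to compound 4 (within the scatter), so on this second core too the change left the read-out within the scatter. Set beside the earlier step, the change shows no difference between the two cores that can be told apart from the scatter: the same change on two cores in this assay, a number 4 percentage points lower (within the scatter) from compound 1 to compound 3 and a number 5 percentage points higher (within the scatter) from compound 2 to compound 4, 9 percentage points apart, within the scatter of two such steps What this supports is a modest statement: on these two cores, with the entering chloro ortho to a chloro group in one case and placed differently in the other, the change produced no step beyond the scatter. It does not show that the change has one fixed direction or size, and two small steps at a single concentration cannot say how it would behave on a further core.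

Going by these compounds, whether a group other than chloro on this ring, such as methoxy, nitrile or an amine, would give a step beyond the scatter stays open. So does the effect of a longer chain on the other half of the urea.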